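A few compounds are considered here, and "the series" means these few. Any claim that something is new, unique, unknown or untested is made for them only; others in the source may bear on it.

Measured in a physicochemical assay for solubility, with a stated time of 24 h, tested at 30 mg/mL; a higher number here means a more soluble compound, a lower number a less soluble compound:
- compound 1 `O=C(CCCCCCNc1c(Nc2ccccc2)c(=O)c1=O)NO`: 1800000 nM
- compound 2 `O=C(CCCCCNc1c(Nc2ccccc2)c(=O)c1=O)NO`: 2200000 nM
- compound 3 `Cc1ccc([C@H](C)Nc2c(NCCCCCC(=O)NO)c(=O)c2=O)cc1`: 5600000 nM

In this assay compound 2 at 2200000 nM sits within the scatter of compound 1, while compound 3 at 5600000 nM stands higher, beyond the scatter.

Compound 4 `Cc1ccccc1Nc1c(NCCCCCC(=O)NO)c(=O)c1=O` has not yet been measured. It departs from compound 2 by methyl in place of hydrogen on an aromatic carbon.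

Within the data shown here, no measured step makes this change. The only one, a 1.2-fold higher number from compound 1 to compound 2 (0.09 log units; within the scatter), alters the chain and stays within the scatter, so it gives no basis for a direction. No step beyond the scatter is therefore expected in this assay.

The expected change is a 1.0-fold higher number from compound 2 to compound 4 (0.02 log units; within the scatter).

The estimate for compound 4 is 2300000 nM, with an expected range of 1000000 nM to 5500000 nM.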

Compound 4, solubility: 12000000 nM
Beside the measured number, compound 4's estimate is 5.2-fold (0.72 log units) below it; measured number above the stated range.
By their numbers in this assay, from the lowest: compounds 1 and 2 (each within the scatter of the next); then compound 3; then compound 4.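

In this assay, methyl in place of hydrogen on an aromatic carbon, ortho to a large group, gives a 5.5-fold higher number from compound 2 to compound 4 (0.74 log units; beyond the scatter). Among these compounds, this is the first step at this position, and it lies beyond the scatter, whereas the only earlier step, in the chain, stayed within it. Nothing measured here accounts for the rise.

Going by these compounds, it remains open whether methyl elsewhere on the ring would give a similar step. Also open, on these data alone, is whether ethyl, methoxy or chlorine in the same place would do so.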